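Removing the Methoxy Group from Compound 3

This account rests on a few compounds, and the source may have more. Where it says the series, first, only, none or still open, it means among the compounds named here.

Among the three compounds measured in an assay on isolated protein for inhibition of protein kinase C zeta type (Homo sapiens), with stated times of 1 h and 2.5 min, tested at 30 uM (a higher number here means more inhibition at the concentration tested (going by the name of the read-out), a lower number less inhibition), compound 3 `COc1ccc(-c2csc(N)c2C(=O)OCc2ccccc2)c(F)c1` gives 78%, the second highest number: compound 2 `COc1ccc(-c2csc(N)c2C(=O)OCc2ccccc2)cc1` gives 86%, and compound 1 `CCOC(=O)c1c(-c2ccccc2F)csc1N` gives 62%. Among the measured compounds shown here, the one measured step, a number 8 percentage points lower from compound 2 to compound 3 (within the scatter), concerns adding a fluoro group, not the change now in view. Compound 4 `Nc1scc(-c2ccccc2F)c1C(=O)OCc1ccccc1` differs from compound 3 by hydrogen in place of methoxy on an aromatic carbon. For the measured compounds named here, no measured step covers this exact change, so the expectation rests on the compounds as a whole: compound 1, which carries the same ring, sits lowest, while both benzyl esters sit higher. Compound 4 is therefore expected to give 68%, between 50% and 85%, a step of a number 10 percentage points lower from compound 3 to compound 4 (within the scatter) that is estimated to be modest.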

Compound 4, a percentage reported as inhibition, at one concentration (the size of the read-out at that concentration, not a potency): 57%
Compound 4: middle estimate off by 11 percentage points, on the high side; low and high end bracket the measured number.
By their numbers in this assay, from the lowest: compounds 4 and 1 (each within the scatter of the next); then compounds 3 and 2 (each within the scatter of the next).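

Removing the methoxy group from the aromatic ring matters in this assay, giving a number 21 percentage points lower from compound 3 to compound 4 (beyond the scatter). Exchanging the whole 4-methoxyphenyl group for 2-fluorophenyl likewise gives a number 29 percentage points lower from compound 2 to compound 4 (beyond the scatter), whereas adding fluoro alone to compound 2 had stayed within the scatter. Without the methoxy group, the benzyl ester offers no measurable gain over the ethyl ester: phenyl in place of methyl gives a number 5 percentage points lower from compound 1 to compound 4 (within the scatter).

Nothing available explains why this drop occurs. As far as these compounds go, whether a hydroxyl group, an amine or an ethoxy group on this carbon would behave like methoxy remains open.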